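The source may hold more compounds than are shown below. What is called first, only, known or untested is meant among the compounds shown, and "the series" means these compounds.

Measured so far in a functional assay on the whole organism (strain Sprague-Dawley) for inhibition, with Rattus norvegicus as the target, read by paw edema, with a stated time of 180 min, at a dose of 30 mg/kg by the oral route; on this read-out lower numbers stand for a weaker effect and higher numbers for a stronger effect at the one dose given:
compound 1 `COc1ccnc(CNc2ccc3c(c2)nc(C)n3C[C@@H](O)[C@H]2O[C@H](O)[C@@H](O)[C@H]2O)c1OC` gives 72%
compound 2 `COc1ccnc(CNc2ccc3c(c2)nc(C)n3C[C@@H](O)[C@H]2O[C@H](O)[C@@H](O)[C@H]2O)c1C` gives 58%
compound 3 `COc1c(C)cnc(CNc2ccc3c(c2)nc(C)n3C[C@@H](O)[C@H]2O[C@H](O)[C@@H](O)[C@H]2O)c1C` gives 56%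

Compound 1 stands highest of the three numbers in this assay: the nearest number is a number 14 percentage points lower from compound 1 to compound 2 (beyond the scatter), the furthest is a number 16 percentage points lower from compound 1 to compound 3 (beyond the scatter), and a number 2 percentage points lower from compound 2 to compound 3 (within the scatter).

Compound 4 `COc1ccnc(CNc2ccc3[nH]c(C)nc3c2)c1OC` differs from compound 1 in one place: a hydrogen atom in place of a group of 11 heavy atoms (6 carbon, 5 oxygen; one five-membered non-aromatic ring with 1 hetero atom), on an aromatic nitrogen. Among the compounds with values here, none of the measured steps touches that aromatic nitrogen; all three alter the pyridinyl group on the saturated chain, and the two that went beyond the scatter were modest. The change to compound 4 is therefore without a measured counterpart, and a loss of the whole group of 11 heavy atoms is a far larger change than any step seen, so a drop beyond the scatter is expected, with wide uncertainty. The expected number for compound 4 in this assay is 45%, between 15% and 70%. The expected step is a number 27 percentage points lower from compound 1 to compound 4 (beyond the scatter).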

Compound 4, a percentage reported as inhibition, in the whole organism at one dose (the size of the read-out at that dose, not a potency): 61%
The estimate for compound 4 lay 16 percentage points below the measured number, and the stated range covers the measured number.
By their numbers in this assay, from the lowest: compounds 3, 2 and 4 (each within the scatter of the next); then compound 1.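

In this assay, a hydrogen atom in place of the group of 11 heavy atoms on the aromatic nitrogen gives a number 11 percentage points lower from compound 1 to compound 4 (beyond the scatter) and is a modest step, beyond the scatter. The effect at the one dose given therefore does not depend on that group, as compound 4 still gives 61% without it. No measured evidence explains this step.

On these data alone, whether a methyl group, a longer chain or a carboxylic acid on this nitrogen would give a higher or lower number remains open. So does whether the changes on the pyridinyl group would have the same effect with hydrogen at this position.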